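Trifluoromethyl for Methyl: From Compound 2 to Compound 3

The source may report more compounds than this note shows. Statements on the series, on what has been measured and on what is new or still open speak of the compounds shown alone.

In a functional assay on CHO cells with sphingosine 1-phosphate receptor 2 (Homo sapiens) as the target, read by GTPgammaS binding (on this read-out higher numbers stand for an effect only at larger amounts of compound and lower numbers for an effect already at smaller amounts), compound 1 `Cc1cc(CCC(=O)O)ccc1-c1noc(-c2ccc(OC(C)C)nc2)n1` gives only a limit, > 10000 nM. Compound 2 `Cc1cc(CCC(=O)O)ccc1-c1noc(-c2cnc(OC(C)C)c(Cl)c2)n1` likewise gives only a limit in this assay, > 10000 nM. Going by the values given here, the single measured step, a step that the two limits leave unreadable from compound 1 to compound 2, has no readable size because of the limit of > 10000 nM in this assay, at which 2 of the 2 values shown sit. Among the compounds with values here, compound 2 therefore stands at the limit of this assay, as does the one other value shown. Compound 3 `Cc1cc(CCC(=O)O)ccc1-c1noc(-c2cnc(OC(C)C(F)(F)F)c(Cl)c2)n1` differs from compound 2 by trifluoromethyl in place of methyl on a saturated chain carbon bound to an oxygen on an aromatic ring and a saturated chain carbon. Within the data shown here, no measured step involves this kind of change, and the only measured step gives no size, so there is nothing to suggest that compound 3 would move beyond the scatter in either direction. The expected value for compound 3 in this assay is therefore 15000 nM, within a range from 3000 nM to 60000 nM, and most likely again reported only as a limit. This estimate corresponds to an expected step that the limit leaves unreadable from compound 2 to compound 3.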

Compound 3, half-maximal effective concentration: > 10000 nM
Compound 3: only a limit was reported; the forecaster's own chance of this, stated with the estimate: 80%; the middle value is on the limit's open side.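

Compound 2 and compound 3 both give only a limit, so no size can be read for the step between them: (the limit of > 10000 nM in this assay, at which 3 of the 3 values shown sit). The compounds shown leave open what effect, if any, the trifluoromethyl in place of methyl has in this assay once values fall inside the measurable range.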